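The source may report more compounds than this note shows. Statements on the series, on what has been measured and on what is new or still open speak of the compounds shown alone.

Measured so far:
compound 1 `CN1CC2(C1)CN(c1ccc(OCc3ccccc3)c(C(=O)Nc3ccnnc3)c1)C2` — 198000 nM
compound 2 `O=C(Nc1ccnnc1)c1cc(N2CCC(F)CC2)ccc1OCc1ccccc1` — 20000 nM

In a physicochemical assay for solubility, measured as kinetic solubility (a lower number here means a less soluble compound, a higher number a more soluble compound), compound 1 gives 198000 nM, the highest of the two numbers on hand, while compound 2 gives 20000 nM. Among the compounds with values here, the only measured step is a 9.9-fold lower number from compound 1 to compound 2 (1.00 log units; beyond the scatter), which swaps the pair of four-membered rings for a six-membered ring carrying fluorine on the same aromatic carbon.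

Compound 3 `O=C(Nc1ccnnc1)c1cc(N2CCC(O)CC2)ccc1OCc1ccccc1` differs from compound 1 in one place:
a group of 7 heavy atoms (5 carbon, 1 nitrogen, 1 oxygen; one six-membered non-aromatic ring with 1 hetero atom) in place of a group of 8 heavy atoms (6 carbon, 2 nitrogen; 2 four-membered non-aromatic rings with 1 hetero atom each), on an aromatic carbon

The step from compound 1 to compound 2 is the one that bears on this change, since the group that leaves and the place are the same and the entering group is again a six-membered non-aromatic ring with one hetero atom, here 4-hydroxypiperidin-1-yl with one hydrogen-bond donor rather than fluorine. Within the data shown here, no measured pair shows how the hydroxyl and the fluorine compare, so the expectation is a drop in the direction of compound 2 but of uncertain size, estimated at a 3.3-fold lower number from compound 1 to compound 3 (0.52 log units; beyond the scatter). Compound 3 is therefore expected to give about 60000 nM, within 20000 nM to 180000 nM.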

Compound 3, solubility: 28000 nM
Compound 3: the middle estimate sits 2.1-fold (0.33 log units) above what was measured, and the stated range covers the measured number.
By their numbers in this assay, from the lowest: compounds 2 and 3 (each within the scatter of the next); then compound 1.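

In this assay, a second six-membered replacement on the aromatic carbon para to a benzyloxy group also lands well short of compound 1, with a 7.1-fold lower number from compound 1 to compound 3 (0.85 log units; beyond the scatter). Hydroxy in place of fluoro on a saturated ring carbon gives a 1.4-fold higher number from compound 2 to compound 3 (0.15 log units; within the scatter), so this assay does not separate the two substituents, and compound 2 and compound 3 stand together against compound 1. Among the three compounds, the higher number goes only with the group holding the two four-membered rings, and neither compound with a six-membered ring goes against this; no measurement on hand gives a reason for these numbers.

Still open, from the compounds shown here alone, is whether the number for compound 1 follows from the two four-membered rings themselves or from the methyl-bearing ring nitrogen within that group, since both leave together in each step. Also open, going by these compounds, is how this assay would respond to an amine such as dimethylamino, or to a carboxylic acid, on the same saturated ring carbon of the six-membered ring, as neither hydroxy nor fluoro indicates what either group would give.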